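Swapping 4-methylpiperazin-1-yl for nitro in a cell toxicity test

The source may report more compounds than this note shows. Statements on the series, on what has been measured and on what is new or still open speak of the compounds shown alone.

Measured in an ADME assay on TZM cells (Homo sapiens) for cytotoxicity, read by WST assay, with a stated time of 2 days; on this read-out higher numbers stand for lower toxicity in this test and lower numbers for higher toxicity in this test:
Compound 1 `Cc1c(Cc2c(Cl)cccc2Cl)nc(N(C)Cc2ccc([N+](=O)[O-])cc2)[nH]c1=O`: 19500 nM
Compound 2 `Cc1c(C(C)c2c(F)cccc2F)nc(N(C)Cc2ccc(N3CCN(C)CC3)cc2)[nH]c1=O`: 26200 nM

Compound 2, at 26200 nM, lies within the usual scatter of compound 1, so these two numbers cannot be told apart. Compound 3 `Cc1c(C(C)c2c(F)cccc2F)nc(N(C)Cc2ccc([N+](=O)[O-])cc2)[nH]c1=O` has nitro in place of 4-methylpiperazin-1-yl on an aromatic carbon, para to a large group (nitro in place of 4-methylpiperazin-1-yl on an aromatic carbon). Compound 1 also carries nitro and gives 19500 nM, so no step beyond the scatter is expected in this assay. The expected change is small, a 1.3-fold lower number from compound 2 to compound 3 (0.12 log units; within the scatter). For compound 3 the estimated value is 20000 nM, within a range of 9000 nM to 45000 nM.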

Compound 3, half-maximal cytotoxic concentration: > 50000 nM
Compound 3 ended at the assay's limit; the forecaster's own chance of this, stated with the estimate: 15%; middle value at least 2.5-fold (0.39 log units) from the limit.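

In this assay the reading for compound 3 is a limit and not a number: the limit of > 50000 nM in this assay, at which 1 of the 3 values shown sits. Placing nitro instead of 4-methylpiperazin-1-yl on the aromatic carbon gives an at least 1.9-fold higher number from compound 2 to compound 3 (0.28 log units; that floor lies within the scatter), so this change is not shown to exceed the scatter, though its true size stays unknown. For the compounds shown here, with nitro held fixed, 1-(2,6-difluorophenyl)ethyl in place of 2,6-dichlorobenzyl gives an at least 2.5-fold higher number from compound 1 to compound 3 (0.40 log units; beyond the scatter), the only step here beyond the scatter.

As far as these compounds go, how a simple amine or a carboxylic acid on that aromatic carbon would read remains open. So does whether the step between those two side groups holds with 4-methylpiperazin-1-yl in place of nitro.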